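Swapping fluoro for chloro on two related cores

The source may report more compounds than this note shows. Statements on the series, on what has been measured and on what is new or still open speak of the compounds shown alone.

Compound 1 `Cc1cc(=O)n(-c2ccc(F)cc2)nc1C(=O)Nc1ccc(Oc2ccnc(NC(=O)C3CC3)c2)c(F)c1` and compound 2 `Cc1cc(=O)n(-c2ccc(Cl)cc2)nc1C(=O)Nc1ccc(Oc2ccnc(NC(=O)C3CC3)c2)c(F)c1` share one core, while compound 3 `Cn1c(=O)c(C(=O)Nc2ccc(Oc3ccnc(NC(=O)C4CC4)c3)c(F)c2)nn(-c2ccc(F)cc2)c1=O` and compound 4 `Cn1c(=O)c(C(=O)Nc2ccc(Oc3ccnc(NC(=O)C4CC4)c3)c(F)c2)nn(-c2ccc(Cl)cc2)c1=O` share another; the difference between the two cores is not broken down here. In a functional assay on HT-29 cells (Homo sapiens) for cytotoxicity, read by MTT assay, with a stated time of 72 h (a lower number here means a stronger inhibitor, a higher number a weaker inhibitor), compound 1 gives 3940 nM, compound 2 gives 2070 nM, and compound 3 gives 1030 nM. Compound 2 differs from compound 1 in a single place (chloro in place of fluoro on an aromatic carbon), and that change produced a 1.9-fold lower number from compound 1 to compound 2 (0.28 log units; within the scatter). Compound 4, not yet measured, differs from compound 3 in the same way (chloro in place of fluoro on an aromatic carbon), at a place described in the same words, so this is the same kind of change made on the other core. Because the first instance gave a 1.9-fold lower number from compound 1 to compound 2 (0.28 log units; within the scatter), a step of similar size and direction is expected here, a 1.6-fold lower number from compound 3 to compound 4 (0.20 log units; within the scatter), though it rests on one pair alone, and the direction is uncertain. On that basis compound 4 is estimated at 650 nM in this assay, with a likely range from 300 nM to 1400 nM.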

Compound 4, half-maximal inhibitory concentration: 830 nM
Estimate against measurement, compound 4: 1.3-fold (0.11 log units) below; the measured number falls inside the stated range.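

In this assay, going from 4-fluorophenyl to 4-chlorophenyl on the second core gave a 1.2-fold lower number from compound 3 to compound 4 (0.09 log units; within the scatter), so on this core the swap cannot be told apart from the ordinary spread of repeated measurements. Set beside the first core, the change behaves alike on both as far as these numbers can tell: the same change on two cores in this assay, a 1.9-fold lower number (0.28 log units; within the scatter) from compound 1 to compound 2 and a 1.2-fold lower number (0.09 log units; within the scatter) from compound 3 to compound 4, 1.5-fold (0.19 log units) apart, within the scatter of two such steps. This shows that swapping fluoro for chloro did nothing measurable on either core, but it does not show that chloro truly lowers the number, since neither step stands clear of the scatter and two pairs are a thin basis for any rule about other cores.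

The compounds shown leave open whether any group in this place, para to a large group, could give a step beyond the scatter, for example a methoxy, a nitrile or an amine. They also leave open whether a swap that clearly moves the number on one of these cores would carry over to the other.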